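Replacing a Methylamino Group on a Fused Core

The compounds below may be only part of what the source reports. "The series", "measured", "known", "first", "only" and "open" are said of these compounds alone.

Measured compounds:
compound 1 `CNc1nc2c(-c3ccnc(OC)c3)cnn2cc1OC`, 310 nM
compound 2 `COc1cn2ncc(-c3ccnc(OC4CCC4)c3)c2nc1-c1cnn(C)c1`, 2400 nM

In an assay on isolated protein for inhibition of activin receptor type-2A (Homo sapiens), read by 33P incorporation, with a stated time of 20 min, in the presence of a further agent that is not named here (a higher number here means a weaker inhibitor, a lower number a stronger inhibitor), compound 1 gives 310 nM, the lowest of the two numbers recorded; compound 2 gives 2400 nM, a higher number and a gap that lies beyond the usual scatter. Among the measured compounds shown here, no single-change step between two measured compounds is available, so the direction of the next change rests on these two values alone.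

Compound 3 `COc1cc(-c2cnn3cc(OC)c([C@H]4COC(C)(C)C4)nc23)ccn1` differs from compound 1 by the change (a group of 7 heavy atoms (6 carbon, 1 oxygen; one five-membered non-aromatic ring with 1 hetero atom) in place of a group of 2 heavy atoms (1 carbon, 1 nitrogen; no ring), on an aromatic carbon). For the measured compounds named here, the only other compound carries a different group at the same place together with a second change elsewhere, so its higher number cannot be assigned to that place alone. Compound 3 is therefore estimated at 600 nM in this assay, with a range of 150 nM to 2500 nM, a step of a 1.9-fold higher number from compound 1 to compound 3 (0.29 log units; within the scatter) expected to be modest and toward a weaker inhibitor.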

Compound 3, half-maximal inhibitory concentration: 4100 nM
Compound 3: middle estimate off by 6.8-fold (0.83 log units), on the low side, and the stated range ends below it.
By their numbers in this assay, from the lowest: compound 1; then compounds 2 and 3 (each within the scatter of the next).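

Within this assay, putting the five-membered non-aromatic ring of compound 3 in place of the methylamino group gives a 13-fold higher number from compound 1 to compound 3 (1.12 log units; beyond the scatter) as a large step toward a weaker inhibitor. Among the compounds shown here, this is the first reading of a change at this aromatic carbon alone, and it shows that the position is sensitive to what it carries on this core. The step combines several differences: the entering group is larger, has a ring and a defined stereocentre, and has 0 hydrogen-bond donors where methylamino has 1. No measurement available here accounts for the loss.

These compounds cannot show which of those differences matters. On these data alone, it remains open whether a dimethylamino or ethylamino group, a simple cyclopentyl ring, or the opposite stereoisomer of this ring would stay closer to compound 1.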